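The source may report more compounds than this note shows. Statements on the series, on what has been measured and on what is new or still open speak of the compounds shown alone.

Working notes on the series. Compounds 1 to 3 share one core; compound 1 is `NS(=O)(=O)c1cc(-c2nnc(CN3CCN(c4ccccc4)CC3)o2)c(Cl)cc1SCc1ccccc1`, compound 2 is `CCOC(=O)c1cn(Cc2nnc(-c3cc(S(N)(=O)=O)c(SCc4ccccc4)cc3Cl)o2)nn1` and compound 3 is `NS(=O)(=O)c1cc(-c2nnc(CNC(=O)c3ccccc3)o2)c(Cl)cc1SCc1ccccc1`. In a functional assay on HeLa cells (Homo sapiens) for cytotoxicity, read by MTT assay, with a stated time of 72 h (a higher number here means a weaker inhibitor, a lower number a stronger inhibitor), compound 1 gives 100000 nM, compound 2 gives 122000 nM and compound 3 gives 105000 nM. On these numbers compound 3 stands second highest of three, nearest compound 1 and furthest from compound 2, with all three values within the scatter of one another. The measured steps are a 1.2-fold higher number from compound 1 to compound 2 (0.09 log units; within the scatter), a 1.1-fold higher number from compound 1 to compound 3 (0.02 log units; within the scatter) and a 1.2-fold lower number from compound 2 to compound 3 (0.07 log units; within the scatter); each exchanges the group on the saturated chain carbon and none moves the number beyond the scatter.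

Compound 4 is `NS(=O)(=O)c1cc(-c2nnc(/C=C/c3ccc(Cl)cc3)o2)c(Cl)cc1SCc1ccccc1`. Its change from compound 3 is 2-(4-chlorophenyl)ethenyl in place of benzamidomethyl on an aromatic carbon. The three measured steps bear on this only loosely: they swap groups while the saturated carbon keeps its place, whereas here that carbon and the amide leave together and the chlorophenyl-bearing ethenyl sits directly on the ring carbon. Because compound 3 gives 105000 nM and every measured step lies within the scatter, no step beyond the scatter is expected, though the range is kept wide since the change is of a new kind. The expected step is a 1.2-fold lower number from compound 3 to compound 4 (0.07 log units; within the scatter). Compound 4 is expected at 90000 nM, with a range from 30000 nM to 200000 nM.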

Compound 4, half-maximal inhibitory concentration: 40000 nM
For compound 4 the middle estimate is 2.3-fold (0.35 log units) above the measured one; measured number inside the range.
By their numbers in this assay, from the lowest: compound 4; then compounds 1, 3 and 2 (each within the scatter of the next).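

In this assay, for the compounds shown here, the group on the aromatic carbon of the shared core is the first place where a change shows beyond the scatter: a 2.6-fold lower number from compound 3 to compound 4 (0.42 log units; beyond the scatter) and a 3.1-fold lower number from compound 2 to compound 4 (0.48 log units; beyond the scatter), whereas exchanges that kept the saturated chain carbon stayed within it. The change itself is compound, since 2-(4-chlorophenyl)ethenyl brings in chlorine and a double bond outside aromatic rings bound directly to the ring carbon, while benzamidomethyl takes away the saturated carbon, the amide nitrogen and carbonyl, and its hydrogen-bond donor and acceptor. No measurement is at hand that accounts for the lower number.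

The compounds shown do not separate the share of the chlorine, the ethenyl link and the loss of the amide, which an unsubstituted 2-phenylethenyl and a saturated 2-(4-chlorophenyl)ethyl chain would begin to part. Also open, as far as these compounds go, is whether a carboxylic acid or an amine in place of the chlorine would hold the number near that of compound 4 at 40000 nM.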